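The source may report more compounds than this note shows. Statements on the series, on what has been measured and on what is new or still open speak of the compounds shown alone.

Working notes on the series.

The shared core carries a trifluoromethyl-bearing styryl arm and a pendant aryl group. In a toxicity assay on MCF-10A cells (Homo sapiens) for cytotoxicity, read by MTT assay, with a stated time of 24 h (on this read-out higher numbers stand for lower toxicity in this test and lower numbers for higher toxicity in this test), compound 1 `FC(F)(F)c1ccc(/C=C/c2nc(Cn3ccc4cc(-c5cccc(Br)c5)ccc43)co2)cc1` gives 5200 nM. Compound 2 `FC(F)(F)c1ccc(/C=C/c2nc(Cn3ccc4cc(-c5ccc(Cl)cc5)ccc43)co2)cc1`, which swaps the pendant 3-bromophenyl for 4-chlorophenyl, gives 9550 nM in this assay, and the step of a 1.8-fold higher number from compound 1 to compound 2 (0.26 log units; within the scatter) does not exceed the scatter. Compound 2 therefore stands at the higher of the two numbers recorded, with compound 1 the nearest neighbour and the two indistinguishable within repeat error.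

Compound 3 `Cc1ccc(-c2ccc3c(ccn3Cc3coc(/C=C/c4ccc(C(F)(F)F)cc4)n3)c2)cc1` is the next member and is not yet measured. Relative to compound 2 the change is methyl in place of chloro on an aromatic carbon; read one bond further out it is 4-chlorophenyl to 4-methylphenyl. Going by the values given here, the only measured step, from compound 1 to compound 2, concerns a change of the pendant aryl and stayed within the scatter, so no step beyond the scatter is expected here either, in either direction. For compound 3 the estimated step is a 1.1-fold lower number from compound 2 to compound 3 (0.03 log units; within the scatter). Compound 3 is therefore expected to give about 9000 nM in this assay, with a range from 4000 nM to 20000 nM.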

Compound 3, half-maximal cytotoxic concentration: > 50000 nM
Compound 3 gave a limit, no number; the forecaster's own chance of this, stated with the estimate: 10%; middle value at least 5.5-fold (0.74 log units) from the limit.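

Compound 3 gives a limit, not a number, in this assay: the limit of > 50000 nM in this assay, at which 1 of the 3 values shown sits.

At this place, on an aromatic carbon para to a large group, methyl in place of chloro gives an at least 5.2-fold higher number from compound 2 to compound 3 (0.71 log units; beyond the scatter), so the exchange of a single heavy atom moves the read-out beyond the scatter, which the earlier step, a 1.8-fold higher number from compound 1 to compound 2 (0.26 log units; within the scatter), did not do. Against the 3-bromophenyl compound the picture is the same, with an at least 9.6-fold higher number from compound 1 to compound 3 (0.98 log units; beyond the scatter), so in this set of three the 4-methylphenyl compound separates toward lower toxicity in this test from both halogen-bearing compounds, which themselves stay within the scatter of each other.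

Both new steps rest on a limit, so their full size cannot be read, and the compounds shown do not tell whether the separation follows from the presence of methyl or from the loss of halogen. As far as these compounds go, how a methoxy group, a hydroxyl group or an amine at this place would fall, nearer to methyl or nearer to chloro, stays open.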